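This account rests on a few compounds, and the source may have more. Where it says the series, first, only, none or still open, it means among the compounds named here.

Compound 2 `CC(C)(C)COC(=O)N1CCC(Oc2ncnc3c2CCN3c2ccc(S(C)(=O)=O)cc2F)CC1` gives the lowest number of the two measured in a functional assay on CHO-K1 cells for agonist activity at Glucose-dependent insulinotropic receptor (Homo sapiens), read by a luciferase reporter, with a stated time of 5 h (on this read-out lower numbers stand for an effect already at smaller amounts and higher numbers for an effect only at larger amounts of compound), namely 39.8 nM; compound 1 `CCOC(=O)N1CCC(Oc2ncnc3c2CCN3c2ccc(S(C)(=O)=O)cc2F)CC1` gives 251 nM. Compound 3 `CS(=O)(=O)c1ccc(N2CCc3c(OC4CCN(C(=O)OCCF)CC4)ncnc32)c(F)c1` differs from compound 2 by fluoromethyl in place of tert-butyl on a saturated chain carbon bound to an oxygen next to a carbonyl group. Going by the values given here, the one measured step at this position, a 6.3-fold lower number from compound 1 to compound 2 (0.80 log units; beyond the scatter), went with the larger group. Compound 3 carries a group of a size nearer to that of compound 1, so a step back toward compound 1 is expected, roughly the reverse of a 6.3-fold lower number from compound 1 to compound 2 (0.80 log units; beyond the scatter), giving a 5.0-fold higher number from compound 2 to compound 3 (0.70 log units; beyond the scatter). For compound 3 in this assay a value of 200 nM is therefore estimated, within a range of 70 nM to 630 nM.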

Compound 3, half-maximal effective concentration: 501 nM
Compound 3: the middle estimate sits 2.5-fold (0.40 log units) below what was measured; low and high end bracket the measured number.
By their numbers in this assay, from the lowest: compound 2; then compounds 1 and 3 (each within the scatter of the next).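

In this assay the swap of tert-butyl for fluoromethyl gives a 13-fold higher number from compound 2 to compound 3 (1.10 log units; beyond the scatter) and so undoes more than the earlier gain at this position, while fluoro in place of hydrogen on the chain gives a 2.0-fold higher number from compound 1 to compound 3 (0.30 log units; within the scatter) and stays inside the usual scatter. Among these three compounds, only the neopentyl carbamate stands apart from the other two. No measurement shown here accounts for this. Open, as far as these compounds go, is whether the lower number follows the branching of tert-butyl or the carbon count alone, which an unbranched butyl chain or isopropyl would separate. A cyclopropyl or trifluoromethyl group at this place also remains untested in what is shown.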